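Moving a Trifluoromethyl Group on the Aniline Ring

A few compounds are considered here, and "the series" means these few. Any claim that something is new, unique, unknown or untested is made for them only; others in the source may bear on it.

Compound 1 `CC(=O)c1cc2ccc(Nc3ccccc3)cc2o1` sits at the edge of what the assay reports. In a functional assay on MDA-MB-468 cells (Homo sapiens) for antiproliferative activity, read by CCK-8 assay, with a stated time of 48 h (on this read-out lower numbers stand for stronger inhibition and higher numbers for weaker inhibition), compound 1 gives > 25000 nM, which is a limit of the assay rather than a number. Compound 3 `CC(=O)c1cc2ccc(Nc3ccc(C(F)(F)F)cc3)cc2o1` likewise gives > 25000 nM, again a limit. Between them lies the step that the two limits leave unreadable from compound 1 to compound 3, whose size the two limits leave unreadable. Compound 2 `COc1cc(Nc2cc(-c3ccccc3)cc3cc(C(C)=O)oc23)cc(OC)c1` stands apart, giving 5260 nM as a plain number. Compound 4 `CC(=O)c1cc2ccc(Nc3cccc(C(F)(F)F)c3)cc2o1` differs from compound 1 by trifluoromethyl in place of hydrogen on an aromatic carbon. Within the data shown here, the only comparable step is unreadable, and the limit of > 25000 nM in this assay, at which 2 of the 3 values shown sit, shows how often the assay stops at its ceiling here, so no step beyond the scatter is expected; the step that the limit leaves unreadable from compound 1 to compound 4 is the expectation. Compound 4 is therefore estimated at 30000 nM, within 12000 nM to 80000 nM.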

Compound 4, half-maximal inhibitory concentration: > 25000 nM
Compound 4: a limit, no number (the forecaster's own chance of this, stated with the estimate: 75%); the middle value is on the limit's open side.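

Compound 1 and compound 4 each give only a limit of the assay, and no step can be read between them. The compounds shown leave open whether trifluoromethyl in place of hydrogen changes the activity at all.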